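From trifluoromethyl to cyano, with only limits to go on

The compounds below may be only part of what the source reports. "The series", "measured", "known", "first", "only" and "open" are said of these compounds alone.

Measured so far:
- compound 1 `CCN(CC)c1ccc(-c2cccc(Cl)c2)nn1` gives > 25000 nM (a limit)
- compound 2 `CCN(CC)c1ccc(-c2cccc(C(F)(F)F)c2)nn1` gives > 25000 nM (a limit)

In a functional assay on Caco-2 cells (Homo sapiens) for antiproliferative activity, with a stated time of 48 h (on this read-out lower numbers stand for stronger inhibition and higher numbers for weaker inhibition), compound 2 stands at > 25000 nM as a limit of the assay and not as a number. Its position can therefore be told only through that limit, and no exact strength can be given for it. The whole measured picture so far is the limit of > 25000 nM in this assay, at which 2 of the 2 values shown sit, and nothing in it falls inside the measurable range.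

Going by the values given here, the one measured step is a step that the two limits leave unreadable from compound 1 to compound 2 and it offers no size to carry forward. Compound 3 `CCN(CC)c1ccc(-c2cccc(C#N)c2)nn1` differs from compound 2 in one place: cyano in place of trifluoromethyl on an aromatic carbon, meta to a large group (cyano in place of trifluoromethyl on an aromatic carbon). With no readable step to lean on, no direction can be argued for in this assay and no readable change is expected. The expected result is a step that the limit leaves unreadable from compound 2 to compound 3 and a report of the same limit is the likeliest outcome. For compound 3 the estimated value is 30000 nM (expected range 10000 nM to 50000 nM).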

Compound 3, half-maximal inhibitory concentration: > 25000 nM
Compound 3 was reported as a limit (the forecaster's own chance of this, stated with the estimate: 75%); the middle value lies beyond the limit too.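

Going by these compounds alone, no step among compound 1, compound 2 and compound 3 can be read in this assay, and all three stand at a single limit of the assay, not at a number: the limit of > 25000 nM in this assay, at which 3 of the 3 values shown sit. These compounds leave open how strong each one actually is, and whether exchanging chloro, trifluoromethyl and cyano changes the read-out at all.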